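The source may hold more compounds than are shown below. What is called first, only, known or untested is meant among the compounds shown, and "the series" means these compounds.

Measured so far in an assay on isolated protein for binding affinity to Sigma non-opioid intracellular receptor 1 (Rattus norvegicus); a lower number here means a stronger inhibitor, a higher number a weaker inhibitor:

Compound 1 `COc1ccc(C2NCCc3ccccc32)cc1` — 2200 nM
Compound 2 `Fc1ccc(C2NCCc3ccccc32)cc1` — 1800 nM
Compound 3 `C=CCN1CCc2ccsc2C1c1ccccc1` — 20000 nM

Going by the values given here, compounds 1 and 2 share one core and differ only in the group on the aromatic ring; the step of a 1.2-fold lower number from compound 1 to compound 2 (0.09 log units; within the scatter) is the only single-change step among the measured compounds. Compound 3 has a different core and gives the highest of the three numbers; compound 1, the nearest, and compound 2, the furthest, both give lower numbers, and both gaps lie beyond the scatter.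

Compound 4 `C=CCN1CCc2ccsc2C1C(C)C` is not yet measured. Relative to compound 3 the change is isopropyl in place of phenyl on a saturated ring carbon. Among the compounds with values here, no measured step bears directly on this change: the step of a 1.2-fold lower number from compound 1 to compound 2 (0.09 log units; within the scatter) swaps one substituent on the aromatic ring and leaves the ring in place, so it says nothing about removing the ring altogether. The expectation therefore rests on compound 3 alone. With the aromatic ring gone and the starting number already the highest in the set, compound 4 is expected to give a weaker number again, with a step of about a 2.0-fold higher number from compound 3 to compound 4 (0.30 log units; within the scatter) in this assay. The estimate for compound 4 is 40000 nM, expected to lie between 12000 nM and 130000 nM, with a real chance that only a limit is reported.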

Compound 4, half-maximal inhibitory concentration: 5000 nM
Compound 4: the middle estimate sits 8.0-fold (0.90 log units) above what was measured, outside the stated range (below it).
By their numbers in this assay, from the lowest: compounds 2 and 1 (each within the scatter of the next); then compound 4; then compound 3.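

At this saturated ring carbon, next to the ring nitrogen, an aromatic ring is not required for binding in this assay: isopropyl in place of phenyl gives a 4.0-fold lower number from compound 3 to compound 4 (0.60 log units; beyond the scatter). The earlier single-change step only swapped a substituent on a retained aromatic ring and stayed within the scatter, whereas this change shows that the number responds to the group at this carbon, and that removing the ring here does not worsen it. Nothing available explains this shift.

Open, from the compounds shown here alone, is whether a methyl, a cyclohexyl or a longer chain such as n-butyl at this carbon would move the number further, and whether replacing phenyl with isopropyl would act the same way on the core of compound 1. The role of the allyl group also remains open, as no benzyl or other group at that ring atom is shown.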